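A Sulfonamide Arm Replaces the Pentylphenyl Group

The source may report more compounds than this note shows. Statements on the series, on what has been measured and on what is new or still open speak of the compounds shown alone.

Three measured compounds share one core and differ in the group that hangs from a five-membered aromatic ring with three nitrogens. Compound 1 `O=C1O[C@H]([C@@H](O)Cn2cc(-c3cc(C(F)(F)F)cc(C(F)(F)F)c3)nn2)C(OCc2ccccc2)=C1OCc1ccccc1` is tested in a functional assay on A549 cells (Homo sapiens) for antiproliferative activity, read by MTT assay, with a stated time of 72 h (on this read-out higher numbers stand for weaker inhibition and lower numbers for stronger inhibition), and compound 1 gives 28900 nM. Compound 2 `Cc1ccc(-c2cn(C/C=C3\OC(=O)C(OCc4ccccc4)=C3OCc3ccccc3)nn2)cc1` reaches only a limit in this assay, and compound 2 is recorded as > 100000 nM, so no number exists for it (the limit of > 100000 nM in this assay, at which 1 of the 3 values shown sits). Compound 3 `CCCCCc1ccc(-c2cn(C[C@H](O)[C@H]3OC(=O)C(OCc4ccccc4)=C3OCc3ccccc3)nn2)cc1` gives 6220 nM in this assay, the lowest of the two numbers available, with compound 1 sitting higher by a gap beyond the usual scatter.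

Compound 4 `O=C1O[C@H]([C@@H](O)Cn2cc(CNS(=O)(=O)c3ccc(Cl)cc3)nn2)C(OCc2ccccc2)=C1OCc1ccccc1` has not been measured. It differs from compound 3 in one place: (((4-chlorophenyl)sulfonyl)amino)methyl in place of 4-pentylphenyl on an aromatic carbon. For the measured compounds named here, no pair of measured compounds shows an exchange of this kind, so the size of the step has to be estimated rather than read from the data. Because compound 1 gives 28900 nM while compound 3 gives 6220 nM, the group on this ring can shift the number by a gap of that size, and a shift of similar size is expected here, toward weaker inhibition, as a 3.2-fold higher number from compound 3 to compound 4 (0.51 log units; beyond the scatter). Compound 4 is therefore expected to give about 20000 nM in this assay, with a likely range from 5000 nM to 80000 nM.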

Compound 4, half-maximal inhibitory concentration: 2870 nM
The estimate for compound 4 lay 7.0-fold (0.84 log units) above the measured number; the measured number lies below the stated range.
By their numbers in this assay, from the lowest: compound 4; then compound 3; then compound 1. At a limit, above all of these: compound 2.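

In this assay, replacing 4-pentylphenyl with (((4-chlorophenyl)sulfonyl)amino)methyl gives a 2.2-fold lower number from compound 3 to compound 4 (0.34 log units; beyond the scatter), a modest step but one toward stronger inhibition. Compounds 1, 2 and 3 all carry a phenyl ring bonded directly to the aromatic carbon of the five-membered ring, so compound 4 shows that activity at this position does not depend on that direct bond and survives a very different arm, one that brings in a hydrogen-bond donor and two hydrogen-bond acceptors where the 4-pentylphenyl group has none. The exchange alters several features at once, and no measurement shown here explains why the number falls.

The compounds shown leave open which part of the new arm matters: the chlorine, the sulfonyl group, the amino hydrogen or the methyl link to the ring. Analogues with a carbonyl in place of the sulfonyl group, with a hydrogen or a methoxy group in place of the chlorine, or with a longer chain between the nitrogen and the five-membered ring could begin to separate these parts.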